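This account rests on a few compounds, and the source may have more. Where it says the series, first, only, none or still open, it means among the compounds named here.

Measured so far in a functional assay on the whole organism (Ear) for inhibition, with Mus musculus as the target, with a stated time of 30 min, at a dose of 100 mg/kg by the intraperitoneal route; a lower number here means less inhibition, a higher number more inhibition at the dose given (going by the name of the read-out):
compound 1 `Cc1ccc(C(=O)/C=C/c2ccc(/C=N/NC(=O)c3ccccc3)cc2)c(C)c1` gives 0.18%
compound 2 `Cc1ccc(C(=O)/C=C/c2ccc(/C=N/NC(=O)c3ccncc3)cc2)c(C)c1` gives 58.5%
compound 3 `N=C(N)N/N=C/c1ccc(/C=C/C(=O)c2cccc(Cl)c2)cc1` gives 80.7%

Compound 2 holds the second highest of the three values in this assay: compound 3 is higher than compound 2 by a gap beyond the scatter, and compound 1 lower by a larger gap, also beyond the scatter.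

Going by the values given here, the one measured step, a number 58.3 percentage points higher from compound 1 to compound 2 (beyond the scatter), concerns the aryl on the hydrazide carbonyl, not the aryl ketone end.

Compound 4 `O=C(N/N=C/c1ccc(/C=C/C(=O)c2ccc(Cl)cc2Cl)cc1)c1ccncc1` differs from compound 2 by 2,4-dichlorophenyl in place of 2,4-dimethylphenyl on a carbonyl carbon. Among the compounds with values here, no measured step changes the aryl ketone alone. Compound 3 carries chlorine in this part of the molecule and gives the highest value, but it differs from compound 2 at the hydrazone end too, so the two values alone settle nothing.

The step of a number 1.5 percentage points higher from compound 2 to compound 4 (within the scatter) is therefore expected to stay within the scatter, with no firm direction. Compound 4 is estimated at 60%, in the range 35% to 85%.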

Compound 4, a percentage reported as inhibition, in the whole organism at one dose (the size of the read-out at that dose, not a potency): 83.8%
Compound 4: middle estimate off by 23.8 percentage points, on the low side, within the range that was stated.
By their numbers in this assay, from the lowest: compound 1; then compound 2; then compounds 3 and 4 (each within the scatter of the next).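

In this assay, 2,4-dichlorophenyl in place of 2,4-dimethylphenyl on a carbonyl carbon gives a number 25.3 percentage points higher from compound 2 to compound 4 (beyond the scatter), so the aryl ketone end also moves the read-out, a point the earlier step at the hydrazide aryl could not show. The swap exchanges methyl groups for chlorine atoms on the same aromatic ring, with the heavy-atom count unchanged and no hydrogen-bond donor or acceptor on either side. No measurement here accounts for the size or direction of this step.

Still open, on these data alone, is whether a methoxy or trifluoromethyl group on this aryl ring would give a similar value, and whether both chlorine atoms are needed. Also open, as far as these compounds go, is whether the step of a number 58.3 percentage points higher from compound 1 to compound 2 (beyond the scatter) holds when the ketone carries 2,4-dichlorophenyl.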